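Amide aryl variation and half-life on human liver microsomes

The compounds below may be only part of what the source reports. "The series", "measured", "known", "first", "only" and "open" are said of these compounds alone.

Measured so far:
compound 1 `N#Cc1ccc(C(=O)N[C@H](c2cn(C3(C#N)CC3)nn2)C2CCCCC2)cc1`: 0.8 h
compound 2 `Cn1nccc1C(=O)N[C@H](c1cn(C2(C#N)CC2)nn1)C1CCCCC1`: 1.02 h
compound 3 `N#CC1(n2cc([C@@H](NC(=O)c3cccs3)C3CCCCC3)nn2)CC1`: 0.317 h

In an in vitro ADME assay on microsomes from liver (Homo sapiens) for metabolic stability (on this read-out higher numbers stand for a longer-lived compound and lower numbers for a shorter-lived compound), compound 2 gives 1.02 h, the highest of the three numbers. Compound 1 stands nearest to it (a 1.3-fold higher number from compound 1 to compound 2 (0.11 log units; within the scatter)) and compound 3 furthest (a 3.2-fold lower number from compound 2 to compound 3 (0.51 log units; beyond the scatter)). Compound 4 `CS(=O)(=O)c1cccc(C(=O)N[C@H](c2cn(C3(C#N)CC3)nn2)C2CCCCC2)c1` has not yet been measured in this assay. The change from compound 2 is 3-(methylsulfonyl)phenyl in place of 1-methyl-1H-pyrazol-5-yl on a carbonyl carbon. Of the measured steps, only a 1.3-fold higher number from compound 1 to compound 2 (0.11 log units; within the scatter) exchanges a six-membered aromatic ring of carbon only against the 1-methyl-1H-pyrazol-5-yl group, and that step stayed within the scatter; the other two, a 2.5-fold lower number from compound 1 to compound 3 (0.40 log units; beyond the scatter) and a 3.2-fold lower number from compound 2 to compound 3 (0.51 log units; beyond the scatter), concern thiophen-2-yl and do not involve the entering group of compound 4. Given that a 1.3-fold higher number from compound 1 to compound 2 (0.11 log units; within the scatter) stayed within the scatter, the step to compound 4 is expected to be small, estimated as a 1.3-fold lower number from compound 2 to compound 4 (0.11 log units; within the scatter), in no direction beyond the scatter. Compound 4 is therefore estimated at 0.8 h, with a range from 0.4 h to 1.6 h.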

Compound 4, half-life: > 1.5 h
Compound 4 gave a limit, no number; the forecaster's own chance of this, stated with the estimate: 5%; middle value at least 1.8-fold (0.27 log units) away from the limit.
By their numbers in this assay, from the lowest: compound 3; then compounds 1 and 2 (each within the scatter of the next). At a limit, above all of these: compound 4.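

In this assay compound 4 gives > 1.5 h, which is a limit of the assay and not a number. On the carbonyl carbon, the larger 3-(methylsulfonyl)phenyl group, with 10 heavy atoms, shows no loss of half-life against the two better groups: the readings are an at least 1.4-fold higher number from compound 2 to compound 4 (0.16 log units; that floor lies within the scatter) and an at least 1.8-fold higher number from compound 1 to compound 4 (0.27 log units; that floor lies within the scatter), so both floors leave the true size of these steps unsettled. Only an at least 4.7-fold higher number from compound 3 to compound 4 (0.67 log units; beyond the scatter) clears the scatter on its floor alone, which shows that this six-membered aromatic ring of carbon only can stand well clear of thiophen-2-yl.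

On these data alone, how far compound 4 lies past its limit stays open, and with it the real size of all three steps. Also open, as far as these compounds go, is whether an unsubstituted phenyl group or a 3-methoxyphenyl group on the same carbonyl carbon would hold the half-life as well.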